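The source may hold more compounds than are shown below. What is called first, only, known or untested is meant among the compounds shown, and "the series" means these compounds.

Compound 1 `CS(=O)(=O)c1ccc(COc2ccc(Cl)cc2CN2CCN(C(=O)CNC(=O)C3CC34CCC(F)(F)CC4)CC2)cc1`: > 2 h
Compound 2 `CS(=O)(=O)c1ccc(COc2ccc(Cl)cc2CN2CCN(C(=O)CNC(=O)CC3CCC(F)(F)CC3)CC2)cc1`: > 2 h

In an ADME assay on microsomes from liver (Mus musculus) for metabolic stability, read by LC-MS, using NADPH, with a stated time of 60 min, tested at 1 uM, in the presence of a further agent that is not named here (on this read-out lower numbers stand for a shorter-lived compound and higher numbers for a longer-lived compound), compound 1 gives > 2 h, which is a limit of the assay and not a number. Compound 2 gives > 2 h, also a limit. Both values sit at one mark: the limit of > 2 h in this assay, at which 2 of the 2 values shown sit.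

Compound 3 `CS(=O)(=O)c1ccc(CNc2ccc(Cl)cc2CN2CCN(C(=O)CNC(=O)C3CC34CCC(F)(F)CC4)CC2)cc1` changes compound 1 in one place: (4-(methylsulfonyl)benzyl)amino in place of (4-(methylsulfonyl)benzyl)oxy on an aromatic carbon. This place is on an aromatic carbon, para to a chloro group.

Within the data shown here, the only measured step, a step that the two limits leave unreadable from compound 1 to compound 2, concerns a different group, on a carbonyl carbon, so it gives no size for this change. With no measured guide, the expected step is a step that the limit leaves unreadable from compound 1 to compound 3, which means no expected change beyond the scatter in either direction.

For compound 3 the estimated half-life is 2.5 h, with an expected range of 1.2 h to 6 h.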

Compound 3, half-life in the Mus musculus assay: 1.45 h
For compound 3 the middle estimate is 1.7-fold (0.24 log units) above the measured one; low and high end bracket the measured number.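

In the Mus musculus assay, (4-(methylsulfonyl)benzyl)amino in place of (4-(methylsulfonyl)benzyl)oxy gives an at least 1.3-fold lower number from compound 1 to compound 3 (0.13 log units; that floor lies within the scatter), so a change at this position can at last be given a size, if only a lower bound. Compound 3 is the first compound shown with a half-life that is a number and not a limit of the assay: the limit of > 2 h in the Mus musculus assay, at which 2 of the 3 values shown sit.

In a physicochemical assay for solubility, read by HPLC, in phosphate buffer, measured as kinetic solubility, at pH 7.4 (a higher number here means a more soluble compound, a lower number a less soluble compound), compound 1 gives 10000 nM and compound 3 gives 4000 nM so the same change comes with lower solubility: the measured solubility of compound 1, 10000 nM, and of compound 3, 4000 nM, a 2.5-fold lower number (0.40 log units; beyond the scatter)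

On these data alone, the full size of the half-life change stays open, and the step between the two limits, from compound 1 to compound 2, cannot be read. As far as these compounds go, whether a thioether or an N-methyl amine in this place would hold half-life and solubility is also open.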